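The source may hold more compounds than are shown below. What is called first, only, known or untested is meant among the compounds shown, and "the series" means these compounds.

Compound 1 `Cc1ccccc1N(C)C(=O)c1ccc(-c2ccc(OS(N)(=O)=O)cc2)o1` gives 28 nM in an assay on T47D cells for inhibition of Steryl-sulfatase (Homo sapiens), read by HPLC, with a stated time of 24 h; a lower number here means a stronger inhibitor, a higher number a weaker inhibitor.
Compound 2 `Cc1cccc(F)c1N(C)C(=O)c1ccc(-c2ccc(OS(N)(=O)=O)cc2)o1` gives 150 nM in this assay.
Compound 3 `Cc1ccc(F)cc1N(C)C(=O)c1ccc(-c2ccc(OS(N)(=O)=O)cc2)o1` gives 40 nM in this assay.

Among these three numbers compound 3 stands second highest. Its nearest neighbour is compound 1: the step of a 1.4-fold higher number from compound 1 to compound 3 (0.15 log units; within the scatter) lies within the scatter, so the two cannot be told apart on these data. Its furthest is compound 2, and the step of a 3.8-fold lower number from compound 2 to compound 3 (0.57 log units; beyond the scatter) is modest but beyond the scatter.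

Compound 4 `Cc1cc(F)ccc1N(C)C(=O)c1ccc(-c2ccc(OS(N)(=O)=O)cc2)o1` has not yet been measured. It differs from compound 3 in one place: 4-fluoro-2-methylphenyl in place of 5-fluoro-2-methylphenyl on an amide-type nitrogen. The atoms are the same; only the carbon that carries the fluorine within the ring on the amide-type nitrogen is different.

Two measured steps speak to such a change, both placing fluoro in place of hydrogen on an aromatic carbon of compound 1: the step of a 5.4-fold higher number from compound 1 to compound 2 (0.73 log units; beyond the scatter) was a modest loss, while the step of a 1.4-fold higher number from compound 1 to compound 3 (0.15 log units; within the scatter) stayed within the scatter. So one placement of the fluorine cost something and another cost nothing measurable; the placement in compound 4 is untested. The expected step is therefore small, a 1.1-fold higher number from compound 3 to compound 4 (0.05 log units; within the scatter), leaning towards a slightly higher number or none beyond the scatter. Compound 4 is estimated at 45 nM, with a likely range from 20 nM to 120 nM.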

Compound 4, half-maximal inhibitory concentration: 14 nM
For compound 4 the middle estimate is 3.2-fold (0.51 log units) above the measured one, and the stated range ends above it.
By their numbers in this assay, from the lowest: compounds 4, 1 and 3 (each within the scatter of the next, the first and the last beyond it); then compound 2.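

Moving the fluorine within the ring on the amide-type nitrogen, with the atoms unchanged, gives a 2.9-fold lower number from compound 3 to compound 4 (0.46 log units; beyond the scatter) in this assay, so the carbon that carries the fluorine matters even between two close isomers. The widest gap among the three fluorine placements is an 11-fold lower number from compound 2 to compound 4 (1.03 log units; beyond the scatter), which separates the 4-fluoro-2-methylphenyl group, the best of the three placements, from the 2-fluoro-6-methylphenyl group. Set against the compound with no fluorine on this ring, the 4-fluoro-2-methylphenyl group gives a 2.0-fold lower number from compound 1 to compound 4 (0.30 log units; within the scatter), which lies within the scatter, so this placement of the fluorine is tolerated but cannot be called a gain.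

As far as these compounds go, whether a chlorine atom or a methoxy group on the carbon that carries the fluorine in compound 4 would fare as well remains open, as does the effect of a second fluorine on the same ring. The data shown also offer no explanation of why one placement of the fluorine differs from another.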